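The source may report more compounds than this note shows. Statements on the series, on what has been measured and on what is new or still open speak of the compounds shown alone.

Measured so far in a functional assay on HL-60 cells (Homo sapiens) for cytotoxicity, read by MTT assay, with a stated time of 72 h; on this read-out higher numbers stand for weaker inhibition and lower numbers for stronger inhibition:
- compound 1 `Cc1ccc(S(=O)(=O)n2cc(COC3=C/C(=N\c4ccccc4)c4ccccc4C3=O)nn2)cc1`: 6710 nM
- compound 2 `CC(=O)c1ccc(/N=C2\C=C(OCc3cn(S(=O)(=O)c4ccc(C)cc4)nn3)C(=O)c3ccccc32)cc1`: 5300 nM

Within the data shown here, compound 2 lies within the scatter of compound 1, the only other measured compound, so the two cannot be ranked. Compound 3 `Cc1ccc(S(=O)(=O)n2cc(COC3=C/C(=N\c4ccc(I)cc4)c4ccccc4C3=O)nn2)cc1` is still unmeasured. It differs from compound 2 by 4-acetylphenyl to 4-iodophenyl, that is, iodo in place of acetyl on an aromatic carbon, para to a large group: iodo in place of acetyl on an aromatic carbon.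

Among the measured compounds shown here, the only measured step bearing on this is a 1.3-fold lower number from compound 1 to compound 2 (0.10 log units; within the scatter), with acetyl in place of hydrogen on an aromatic carbon, and it lies within the scatter. For the measured compounds named here, no iodo compound has been measured yet. On that basis, no change beyond the scatter is expected in this assay. The expected step is a 1.1-fold lower number from compound 2 to compound 3 (0.03 log units; within the scatter). For compound 3 the estimate is 5000 nM, with an expected range of 2200 nM to 11000 nM.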

Compound 3, half-maximal inhibitory concentration: 6310 nM
For compound 3 the middle estimate is 1.3-fold (0.10 log units) below the measured one, within the range that was stated.
By their numbers in this assay, from the lowest: compounds 2, 3 and 1 (each within the scatter of the next).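

In this assay, the position para to a large group now carries a third substituent, and the steps are a 1.2-fold higher number from compound 2 to compound 3 (0.08 log units; within the scatter) and a 1.1-fold lower number from compound 1 to compound 3 (0.03 log units; within the scatter). Both lie within the scatter, so iodo, a single heavy atom with no hydrogen-bond acceptor, cannot be told apart here from acetyl or from hydrogen, and the earlier pair alone could not show this for a halogen. No measurement at hand offers an explanation for this flat reading.

As far as these compounds go, it remains open whether this position responds at all to other groups, such as an amine or a carboxylic acid. Also open, from the compounds shown here alone, is whether the same flat reading holds for changes elsewhere on the shared core.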